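The source may hold more compounds than are shown below. What is called first, only, known or untested is meant among the compounds shown, and "the series" means these compounds.

Measured so far:
- Compound 1 `CCn1c(C(=O)Nc2ccc(OC(F)(F)F)cc2)ccc1C(CC)(CC)c1ccc(OCCC(O)(CC)CC)c(C)c1` gives in an ADME assay on L02 cells (Homo sapiens) for antiproliferative activity, read by MTT assay, with a stated time of 48 h; a higher number here means a weaker inhibitor, a lower number a stronger inhibitor > 50000 nM, which is a limit of the assay and not a number.
- Compound 2 `CCC(C)C(NC(=O)c1ccc(C(CC)(CC)c2ccc(OCCC(O)(CC)CC)c(C)c2)n1CC)C(=O)OC` gives in this assay > 50000 nM, again only a limit.
- Compound 3 `CCn1c(C(=O)NC(CC(=O)O)C(=O)OC)ccc1C(CC)(CC)c1ccc(OCCC(O)(CC)CC)c(C)c1` gives in this assay 7590 nM.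

Compound 2 thus stands at the limit of > 50000 nM in this assay, at which 2 of the 3 values shown sit, together with compound 1, and its exact position is not known. The step that the two limits leave unreadable from compound 1 to compound 2 is unreadable for that reason. For the measured compounds named here, the only readable step from compound 2 is an at least 6.5-fold lower number from compound 2 to compound 3 (0.81 log units; beyond the scatter), and the step of an at least 6.5-fold lower number from compound 1 to compound 3 (0.81 log units; beyond the scatter) points the same way: compound 3, carrying the free acid, is the one compound of the three with a number inside the window.

Compound 4 `CCn1c(C(=O)NC(C)CO)ccc1C(CC)(CC)c1ccc(OCCC(O)(CC)CC)c(C)c1` differs from compound 2 by a group of 4 heavy atoms (3 carbon, 1 oxygen; no ring) in place of a group of 9 heavy atoms (7 carbon, 2 oxygen; no ring), on an amide-type nitrogen. This change removes the ester and the branched alkyl and leaves a small hydroxyl-bearing group; it does not introduce the acid that distinguishes compound 3. Going by the values given here, no measured step covers a change of this kind directly, so the expectation rests on compound 2 sitting at the limit and on the single readable step to compound 3. The expected step of an at least 1.2-fold lower number from compound 2 to compound 4 (0.09 log units; that floor lies within the scatter) is therefore small, and a limit remains the likeliest outcome. Compound 4 is estimated at 40000 nM in this assay, within 8000 nM to 120000 nM.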

Compound 4, half-maximal inhibitory concentration: 4840 nM
For compound 4 the middle estimate is 8.3-fold (0.92 log units) above the measured one; the measured number lies below the stated range.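

In this assay, a small hydroxyl-bearing group on the amide-type nitrogen yields a number inside the window without any free carboxylic acid there: an at least 10-fold lower number from compound 2 to compound 4 (1.01 log units; beyond the scatter) and an at least 10-fold lower number from compound 1 to compound 4 (1.01 log units; beyond the scatter), so the acid of compound 3 is not required for a readable value in this series. Compound 3 and compound 4 carry quite different groups at this place, yet they cannot be told apart here, given a 1.6-fold lower number from compound 3 to compound 4 (0.20 log units; within the scatter). The two large steps are floors and not measured sizes, because compound 1 and compound 2 do not give numbers, and the true gap could be wider: the limit of > 50000 nM in this assay, at which 2 of the 4 values shown sit.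

The step between compound 1 and compound 2 cannot be read, and 1-(hydroxymethyl)ethyl differs from the groups of both in several respects at once, so the compounds shown do not separate the role of its hydroxyl from that of its small size. Also open, as far as these compounds go, is whether an amine in place of that hydroxyl, or a longer chain carrying it, would keep the number in the same range.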